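Trimming a Sec-Butoxycarbonyl Group from a Kinase Inhibitor

The compounds below may be only part of what the source reports. "The series", "measured", "known", "first", "only" and "open" are said of these compounds alone.

Of the compounds shown here, three have been tested in an assay on cells for inhibition of Rho-associated protein kinase 2 (Homo sapiens), read by radiometric assay and 33P incorporation, in the presence of a further agent that is not named here; a lower number here means a stronger inhibitor, a higher number a weaker inhibitor. Compound 1 `CCCOC(=O)c1ccc(NC(=O)c2cccc(-c3cc(C(=O)Nc4ccncc4F)ccc3CN)c2)cc1` gives < 1 nM in this assay, which is a limit of the measurement rather than a number. Compound 2 `NCc1ccc(C(=O)Nc2ccncc2F)cc1-c1cccc(NC(=O)c2cc(C(=O)O)ccc2F)c1` likewise gives < 1 nM in this assay, again a limit. Within the data shown here, compound 3 `CCC(C)OC(=O)c1cccc(NC(=O)c2cccc(-c3cc(C(=O)Nc4ccncc4F)ccc3CN)c2)c1` is the one member of the group with a numbered result, giving 2.6 nM in this assay; the other two sit at the limit of < 1 nM in this assay, at which 2 of the 3 values shown sit, so no ordering among the three can be read from these results.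

Compound 4 `NCc1ccc(C(=O)Nc2ccncc2F)cc1-c1cccc(C(=O)Nc2ccccc2)c1` is the next compound to be measured. It differs from compound 3 in one place (hydrogen in place of sec-butoxycarbonyl on an aromatic carbon). Among the measured compounds shown here, no measured pair in the set shows the effect of removing this group, so the expectation rests on the structural change alone. Removing a group of this size usually costs some potency, and the step from compound 3 to compound 4 is expected to be a modest weakening, a 3.8-fold higher number from compound 3 to compound 4 (0.59 log units; beyond the scatter). Compound 4 is therefore estimated at 10 nM in this assay, within a range from 3 nM to 40 nM.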

Compound 4, half-maximal inhibitory concentration: < 1 nM
Compound 4: only a limit was reported (the forecaster's own chance of this, stated with the estimate: 5%); middle value at least 10-fold (1.00 log units) away from the limit.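

Taking the sec-butoxycarbonyl group off this aromatic carbon, meta to a large group, costs no potency; instead the result is an at least 2.6-fold lower number from compound 3 to compound 4 (0.41 log units; beyond the scatter). In this assay compound 4 gives < 1 nM, which is a limit of the assay and not a number. The bare ring carbon is therefore enough at this position, while the step between compound 1 and compound 4 cannot be read, and the compounds at the limit cannot be ordered: the limit of < 1 nM in this assay, at which 3 of the 4 values shown sit.

From the compounds shown here alone, whether a shorter ester such as methoxycarbonyl, or an amine, on this same carbon would also reach the limit stays open. Also open, going by these compounds, is how far compound 4 really lies from compound 3, for the limit hides its true number.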